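The compounds below may be only part of what the source reports. "The series", "measured", "known", "first", "only" and "open" are said of these compounds alone.

Measured so far in a physicochemical assay for lipophilicity; a lower number here means a more polar compound, a higher number a more lipophilic compound:

- Compound 1 `Cc1nc(C)c(C(=O)NCC(=O)Oc2ccc(-c3cc(=O)c4c(O)c(O)c(O)cc4o3)cc2)nc1C`: 2.8
- Compound 2 `Cc1nc(C)c(COC(=O)NCC(=O)Oc2ccc(-c3cc(=O)c4c(O)c(O)c(O)cc4o3)cc2)nc1C`: 2.1

Of these two numbers, compound 2 holds the lower, at 2.1. Compound 3 `Cc1nc(C)c(COC(=O)N[C@H](C)C(=O)Oc2ccc(-c3cc(=O)c4c(O)c(O)c(O)cc4o3)cc2)nc1C` is still unmeasured. It differs from compound 2 by methyl in place of hydrogen on a saturated chain carbon bound to an amide-type nitrogen and a carbonyl carbon.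

Among the compounds with values here, only one measured step is available for comparison, a number 0.70 log units lower from compound 1 to compound 2 (beyond the scatter). Within the data shown here, it concerns a different group, so it offers only a rough sense of scale and no direct precedent. The new change is a smaller edit than that one, so a small rise in this assay is expected, less than the step to compound 2 from compound 1. The expected size is a number 0.30 log units higher from compound 2 to compound 3 (within the scatter). The estimate for compound 3 is 2.4, with an expected range of 2.1 to 2.8.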

Compound 3, partition coefficient: 1.53
Compound 3: the middle estimate sits 0.87 log units above what was measured; measured number outside the range, below it.
By their numbers in this assay, from the lowest: compound 3; then compound 2; then compound 1.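

Methyl in place of hydrogen on a saturated chain carbon bound to an amide-type nitrogen and a carbonyl carbon gives, in this assay, a number 0.57 log units lower from compound 2 to compound 3 (beyond the scatter) on the scale. This shows that the position is not silent: one added carbon, with no ring, no charge and no hydrogen-bond donors or acceptors, is enough to shift the read-out by a modest step. The shift runs toward the lower end of the scale, so for this pair, adding a carbon does not raise the number.

From the compounds shown here alone, whether an ethyl group or a longer chain on the same carbon would continue this downward shift remains open, as does the effect of an amine or a carboxylic acid there. No measurement at hand gives a reason for the direction of this step.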